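A few compounds are considered here, and "the series" means these few. Any claim that something is new, unique, unknown or untested is made for them only; others in the source may bear on it.

Compounds measured in a functional assay on U-87MG ATCC cells (Homo sapiens) for cytotoxicity, read by MTT assay, with a stated time of 72 h; on this read-out lower numbers stand for stronger inhibition and higher numbers for weaker inhibition:
compound 1, `CN(C)CCn1cnnc1-c1cc(Oc2ccc(NC(=O)N/N=C/c3ccccc3O[N+](=O)[O-])cc2F)ccn1`, 7150 nM;
compound 2, `CN(C)CCn1cnnc1-c1cc(Oc2ccc(NC(=O)N/N=C/c3ccccc3)cc2F)ccn1`, 2250 nM;
compound 3, `CN(C)CCn1cnnc1-c1cc(Oc2ccc(NC(=O)N/N=C/c3ccc(F)cc3)cc2F)ccn1`, 2310 nM.

Compound 3 stands second highest of the three numbers in this assay. Its nearest neighbour is compound 2, since a 1.0-fold higher number from compound 2 to compound 3 (0.01 log units; within the scatter); its furthest is compound 1, since a 3.1-fold lower number from compound 1 to compound 3 (0.49 log units; beyond the scatter). Compound 4 is `Cc1cc(/C=N/NC(=O)Nc2ccc(Oc3ccnc(-c4nncn4CCN(C)C)c3)c(F)c2)cc(C)c1O`. It differs from compound 3 in one place: 4-hydroxy-3,5-dimethylphenyl in place of 4-fluorophenyl on a carbon with a double bond to nitrogen.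

Within the data shown here, two measured steps touch the same aromatic group on the carbon with a double bond to nitrogen. Exchanging hydrogen for fluoro there gave a 1.0-fold higher number from compound 2 to compound 3 (0.01 log units; within the scatter), which is within the scatter. Removing nitrooxy gave a 3.2-fold lower number from compound 1 to compound 2 (0.50 log units; beyond the scatter), a modest step. No measured compound carries a hydroxy or methyl group on this ring, so the step to compound 4 in this assay is expected to be small, with no strong reason to expect a number beyond the scatter in either direction. Compound 4 is therefore estimated at 2400 nM, between 1000 nM and 5800 nM, which means an expected 1.0-fold higher number from compound 3 to compound 4 (0.02 log units; within the scatter).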

Compound 4, half-maximal inhibitory concentration: 7710 nM
The estimate for compound 4 lay 3.2-fold (0.51 log units) below the measured number; the whole stated range lies below it.
By their numbers in this assay, from the lowest: compounds 2 and 3 (each within the scatter of the next); then compounds 1 and 4 (each within the scatter of the next).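

In this assay, the aromatic group on the carbon with a double bond to nitrogen proved able to move the number without a nitrooxy group: 4-hydroxy-3,5-dimethylphenyl in place of 4-fluorophenyl gave (a 3.3-fold higher number from compound 3 to compound 4 (0.52 log units; beyond the scatter)), and in place of phenyl it gave (a 3.4-fold higher number from compound 2 to compound 4 (0.53 log units; beyond the scatter)). Set against 2-(nitrooxy)phenyl, the same group gave (a 1.1-fold higher number from compound 1 to compound 4 (0.03 log units; within the scatter)), so these two differently substituted rings stand level. The weaker pair of numbers is therefore not peculiar to nitrooxy, while the phenyl and 4-fluorophenyl compounds form the stronger pair.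

As far as these compounds go, whether the hydroxy or the two methyl groups carry the step stays open, as does how an amine or a carboxylic acid on this ring would read. No evidence on the cause of these steps is at hand.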